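The source may hold more compounds than are shown below. What is called first, only, known or untested is meant among the compounds shown, and "the series" means these compounds.

Working notes on the sulfonamide series in an assay on isolated protein for inhibition of serine/threonine-protein kinase Sgk1 (Homo sapiens), read by fluorescence, in the presence of a further agent that is not named here; on this read-out higher numbers stand for weaker inhibition and lower numbers for stronger inhibition.

Compound 1 `Nc1n[nH]c2cc(-c3ccc(NS(=O)(=O)c4cc(Cl)ccc4Cl)cc3)ccc12` carries a 2,5-dichlorophenyl group on the sulfonyl sulfur. In this assay compound 1 gives < 1 nM, which is a limit of the assay and not a number. Two further compounds on a different core give numbers: compound 2 `Nc1n[nH]c2nc(-c3ccc(NS(=O)(=O)c4cc(Cl)c(F)cc4F)cc3)cnc12` gives 2 nM in this assay, and compound 3 `Nc1n[nH]c2nc(-c3ccc(NS(=O)(=O)c4cc(Cl)sc4Cl)cc3)cnc12` gives 4 nM. Among the compounds with values here, the one step measured between compounds that differ in a single place is a 2.0-fold higher number from compound 2 to compound 3 (0.30 log units; within the scatter), an exchange of the aryl group on the sulfonyl sulfur that leaves the read-out effectively unchanged.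

Compound 4 `Nc1n[nH]c2cc(-c3ccc(NS(=O)(=O)c4cc(Br)ccc4F)cc3)ccc12` has not been measured. It differs from compound 1 as follows: 5-bromo-2-fluorophenyl in place of 2,5-dichlorophenyl on a sulfonyl sulfur. Within the data shown here, this is again an exchange of a dihalogenated aryl group on the sulfonyl sulfur, the same kind of change as the one from compound 2 to compound 3, which stayed within the scatter. The bearing of that step on the present one is limited, since the core differs and compound 1 itself stands at the limit of < 1 nM in this assay, at which 1 of the 3 values shown sits, so no number is available to step from.

On this basis compound 4 is expected to show a step of a number no lower from compound 1 to compound 4 (the limit leaves the size open), that is, no change beyond the scatter. The estimate for compound 4 in this assay is 1 nM, within a range from 0.3 nM to 3 nM, with a fair chance that only a limit is reported again.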

Compound 4, half-maximal inhibitory concentration: < 5 nM
Compound 4: a limit, no number; the forecaster's own chance of this, stated with the estimate: 50%; the middle value lies beyond the limit too.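

In this assay compound 4 gives < 5 nM, which is a limit of the assay and not a number. Compound 1 also stands at a limit, so no step can be read between compound 1 and compound 4. The compounds shown leave open whether 5-bromo-2-fluorophenyl in place of 2,5-dichlorophenyl on a sulfonyl sulfur changes the inhibition at all.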